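The source may report more compounds than this note shows. Statements on the series, on what has been measured and on what is new or still open speak of the compounds shown alone.

Measured compounds:
compound 1, `Cc1ccc(Nc2ncc3c(n2)N(C)C(=O)N(c2cc(NC(=O)c4cccc(C(F)(F)F)c4)ccc2C)C3)cc1N` — 440 nM
compound 2, `Cc1cc(C)cc(C(=O)Nc2ccc(C)c(N3Cc4cnc(Nc5ccc(C)c(N)c5)nc4N(C)C3=O)c2)c1` — > 10000 nM

In an ADME assay on BaF3 cells (Mus musculus) for antiproliferative activity, read by CellTiter-Glo and CCK-8 assay, with a stated time of 72 h (on this read-out higher numbers stand for weaker inhibition of growth and lower numbers for stronger inhibition of growth), compound 1 gives 440 nM. Compound 2 stands at the weak end of the numbers shown: in this assay compound 2 gives > 10000 nM, which is a limit of the assay and not a number, namely (the limit of > 10000 nM in this assay, at which 1 of the 2 values shown sits). For the measured compounds named here, the only measured step is an at least 22-fold higher number from compound 1 to compound 2 (1.35 log units; beyond the scatter), which exchanges the aryl group on the carbonyl carbon. Compound 3, `Cc1cccc(C(=O)Nc2ccc(C)c(N3Cc4cnc(Nc5ccc(C)c(N)c5)nc4N(C)C3=O)c2)c1`, differs from compound 2 by hydrogen in place of methyl on an aromatic carbon, so its aryl group sits between those of compound 1 and compound 2 in pattern. The direction of the measured step suggests that reducing the substitution on that ring may bring the number back down, but a limit for compound 2 leaves the size open. Compound 3 is therefore expected to show an at least 2.0-fold lower number from compound 2 to compound 3 (0.30 log units; that floor lies within the scatter) in this assay, with an estimate of 5000 nM and a likely range from 1000 nM to 20000 nM.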

Compound 3, concentration for 50% growth inhibition: > 10000 nM
Compound 3 was reported as a limit; the forecaster's own chance of this, stated with the estimate: 40%; middle value at least 2.0-fold (0.30 log units) away from the limit.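

In this assay, compound 3 gives > 10000 nM, which is a limit of the assay and not a number. For the compounds shown here, its single methyl group does not recover the activity of compound 1, and the change of trifluoromethyl to methyl on the aromatic carbon alone gives an at least 22-fold higher number from compound 1 to compound 3 (1.35 log units; beyond the scatter), so this replacement is enough for a large loss without the second methyl of compound 2. The step between compound 2 and compound 3 cannot be read, since both values are limits: the limit of > 10000 nM in this assay, at which 2 of the 3 values shown sit.

Going by these compounds, how far compound 2 and compound 3 lie beyond that limit remains open, so any effect of the second methyl is unknown. Also open, on these data alone, is whether chlorine, a methoxy group or a nitrile on that aromatic carbon would bring the number back towards that of compound 1.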